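The source may report more compounds than this note shows. Statements on the series, on what has been measured and on what is new or still open speak of the compounds shown alone.

Compound 1 `COc1ccc(-c2cc(/C=C/C(=O)c3ccc(OC)c(OC)c3)nc3cc(-c4ccccc4)nn23)cc1` is a member of a small set of enone-bridged compounds that share one core and differ in the substitution of the aryl groups at either end. In a functional assay on DU-145 cells (Homo sapiens) for antiproliferative activity, read by MTT assay, with a stated time of 24 h (on this read-out lower numbers stand for stronger inhibition and higher numbers for weaker inhibition), compound 1 gives 16400 nM. Its nearest neighbour in this set is compound 2 `COc1cc(-c2cc(/C=C/C(=O)c3ccc(C)cc3)nc3cc(-c4ccccc4)nn23)cc(OC)c1OC`, which in this assay gives 27100 nM. Among the compounds with values here, the two numbers lie within the scatter of repeated measurements of each other, so nothing can be said about an order between compound 1 and compound 2, and no step between them is drawn here.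

Compound 3 `COc1ccc(C(=O)/C=C/c2cc(-c3ccc(OC)cc3)n3nc(-c4ccccc4)cc3n2)cc1` has not yet been measured. It is reached from compound 1 by a single change: hydrogen in place of methoxy on an aromatic carbon. Within the data shown here, no measured pair in this set isolates that change, so there is no direct precedent for its size. Given that compound 1 at 16400 nM and compound 2 at 27100 nM sit close together despite differing at both ends, the step from compound 1 to compound 3 is expected to be modest, a 1.3-fold higher number from compound 1 to compound 3 (0.13 log units; within the scatter), in the direction of weaker inhibition or none beyond the scatter. Compound 3 is therefore estimated at 22000 nM, with a range from 9000 nM to 55000 nM.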

Compound 3, half-maximal inhibitory concentration: 8500 nM
Estimate against measurement, compound 3: 2.6-fold (0.41 log units) above, and the stated range ends above it.
By their numbers in this assay, from the lowest: compounds 3, 1 and 2 (each within the scatter of the next, the first and the last beyond it).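

In this assay, the change from 3,4-dimethoxyphenyl to 4-methoxyphenyl on the carbonyl side of the enone gives a 1.9-fold lower number from compound 1 to compound 3 (0.29 log units; within the scatter), with hydrogen in place of methoxy on an aromatic carbon. Within the data shown here, this is the first pair in the set that isolates a single change, since compound 1 and compound 2 differ at both ends, and it shows that this methoxy group, ortho to a methoxy group and meta to a large group, can leave without moving the number beyond the scatter. No measurement of any property accompanies the pair, so the result gives no explanation of how this position behaves.

The compounds shown leave open whether this position stays as undemanding when it carries something other than methoxy or hydrogen, such as a hydroxyl group, a fluorine atom, an amine or a longer ether chain. They also leave open whether the remaining methoxy group of the 4-methoxyphenyl ring can give way to hydrogen in the same manner, and whether the same change would read alike with a different aryl group at the other end of the enone.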